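The source may report more compounds than this note shows. Statements on the series, on what has been measured and on what is new or still open speak of the compounds shown alone.

Working notes on the series. The three measured compounds share one core and differ only in the aryl carried on an aromatic carbon. In an ADME assay on microsomes from liver (Homo sapiens) for metabolic stability, tested at 2.5 uM (a higher number here means faster removal of the compound, a lower number slower removal), compound 1 `O=S(=O)(c1ccc(F)c(Cl)c1)c1cnc2cc(F)ccc2c1-c1cccc(Cl)c1` gives 0.66 mL/min, compound 2 `O=S(=O)(c1ccc(F)c(Cl)c1)c1cnc2cc(F)ccc2c1-c1ccc(Cl)cc1` gives 0.39 mL/min and compound 3 `O=S(=O)(c1ccc(F)c(Cl)c1)c1cnc2cc(F)ccc2c1-c1ccc(F)cc1` gives 0.69 mL/min. Compound 2 stands at the lowest of the three numbers, but the spread is small: the step of a 1.7-fold lower number from compound 1 to compound 2 (0.23 log units; within the scatter) lies within the scatter, as do a 1.0-fold higher number from compound 1 to compound 3 (0.02 log units; within the scatter) and a 1.8-fold higher number from compound 2 to compound 3 (0.25 log units; within the scatter). Within the data shown here, on the numbers so far the three compounds cannot be told apart in this assay.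

Compound 4 `O=S(=O)(c1cc(F)cc(F)c1)c1cnc2cc(F)ccc2c1-c1ccc(Cl)cc1` is the next member. Against compound 2 the change sits on the sulfonyl sulfur: 3,5-difluorophenyl in place of 3-chloro-4-fluorophenyl on a sulfonyl sulfur. Among the measured compounds shown here, none of the measured steps touches the aryl on the sulfonyl sulfur; every one of them varies the aryl on the aromatic carbon, and every one stays within the scatter. For the measured compounds named here, no measured step therefore bears directly on this change, and nothing argues for a shift in either direction. The working expectation is a step of a 1.2-fold higher number from compound 2 to compound 4 (0.06 log units; within the scatter), that is, none beyond the scatter. Compound 4 is accordingly estimated at 0.45 mL/min in this assay, with a range of 0.2 mL/min to 1 mL/min.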

Compound 4, intrinsic clearance in a liver preparation (reported as CLH), per the amount of preparation that the assay uses: 0.03 mL/min
For compound 4 the middle estimate is 15-fold (1.18 log units) above the measured one, outside the stated range (below it).
By their numbers in this assay, from the lowest: compound 4; then compounds 2, 1 and 3 (each within the scatter of the next).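

Among these compounds, the aryl on a sulfonyl sulfur is the first place where a single change moves the number in this assay beyond the scatter: 3,5-difluorophenyl in place of 3-chloro-4-fluorophenyl gives (a 13-fold lower number from compound 2 to compound 4 (1.11 log units; beyond the scatter)), whereas every step on the aryl on the aromatic carbon stayed within it. The exchange keeps the count of heavy atoms, replaces one chlorine with one fluorine and leaves hydrogen-bond donors, hydrogen-bond acceptors and net charge as they were, so a large step arises here without any change in those counts. Nothing shown gives a reason for the size of this step.

Going by these compounds, it remains open whether the step depends on the aryl on the aromatic carbon, that is, whether it would also appear with the 3-chlorophenyl of compound 1 or the 4-fluorophenyl of compound 3. On these data alone, it also remains open how the number in this assay responds to other groups on the sulfonyl sulfur, such as a pyridine ring, a cyclohexyl ring or a simple methyl.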